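The source may report more compounds than this note shows. Statements on the series, on what has been measured and on what is new or still open speak of the compounds shown alone.

Of the compounds shown here, two built on one shared core have been measured in a functional assay on MCF7 cells (Homo sapiens) for cytotoxicity, read by MTT assay, with a stated time of 72 h; on this read-out lower numbers stand for stronger inhibition and higher numbers for weaker inhibition. Compound 1 `Cc1ccc(-n2nc(C(=O)Nc3ccc(Oc4ncnc5ccsc45)cc3)c(C)cc2=O)cc1` gives 23800 nM in this assay. Compound 2 `Cc1cc(=O)n(-c2ccc(F)cc2)nc1C(=O)Nc1ccc(Oc2ncnc3ccsc23)cc1` gives 4400 nM in this assay. Among the compounds with values here, the only step recorded, a 5.4-fold lower number from compound 1 to compound 2 (0.73 log units; beyond the scatter), comes from a fluoro in place of methyl on an aromatic carbon. Within the data shown here, compound 2 therefore stands at the lowest of the two numbers, with compound 1 as its only neighbour.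

Compound 3 `Cc1cc(=O)n(-c2ccc(F)c(F)c2)nc1C(=O)Nc1ccc(Oc2ncnc3ccsc23)cc1` has not yet been measured. It differs from compound 2 by fluoro in place of hydrogen on an aromatic carbon, ortho to a fluoro group and meta to a large group, so that 4-fluorophenyl becomes 3,4-difluorophenyl. Among the measured compounds shown here, no measured step matches this change; the closest, a 5.4-fold lower number from compound 1 to compound 2 (0.73 log units; beyond the scatter), concerned a different exchange on the same ring and cannot be carried over directly. A second fluoro is expected to shift the number only modestly, if at all beyond the scatter, so compound 3 is estimated at 3500 nM, within a range from 1500 nM to 9000 nM. That expectation corresponds to a step of a 1.3-fold lower number from compound 2 to compound 3 (0.10 log units; within the scatter).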

Compound 3, half-maximal inhibitory concentration: 5550 nM
For compound 3 the middle estimate is 1.6-fold (0.20 log units) below the measured one, within the range that was stated.
By their numbers in this assay, from the lowest: compounds 2 and 3 (each within the scatter of the next); then compound 1.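

In this assay, the change from 4-fluorophenyl to 3,4-difluorophenyl gives a 1.3-fold higher number from compound 2 to compound 3 (0.10 log units; within the scatter), so on this read-out a fluoro at this place, ortho to a fluoro group and meta to a large group, cannot be told apart from a hydrogen. The new compound also allows a second comparison with the methyl-bearing ring: 3,4-difluorophenyl in place of 4-methylphenyl gives a 4.3-fold lower number from compound 1 to compound 3 (0.63 log units; beyond the scatter), so the difference from compound 1 remains beyond the scatter with the extra fluoro present. Nothing available explains why the second fluoro leaves the number within the scatter or why the two fluorinated rings differ from the 4-methylphenyl ring.

The compounds shown leave open how a chloro, a methoxy group or an amine at this same place on the ring would read, and whether a plain phenyl ring with no fluoro at all would stay close to compound 2. They also leave open how much the rest of the shared core contributes, since every change seen so far lies on this one ring.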